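This account rests on a few compounds, and the source may have more. Where it says the series, first, only, none or still open, it means among the compounds named here.

Measured compounds in a functional assay on KM12 cells (Homo sapiens) for antiproliferative activity; on this read-out higher numbers stand for weaker inhibition of growth and lower numbers for stronger inhibition of growth:
- compound 1 `COc1ccc(-c2nc3ccccc3s2)cc1OC`: in this assay compound 1 gives 74200 nM
- compound 2 `COc1ccc(-c2nc3cc(F)ccc3s2)cc1C`: in this assay compound 2 gives 18600 nM
- compound 3 `COc1ccc(-c2nc3cc(F)ccc3s2)cc1I`: in this assay compound 3 gives 6900 nM

Compound 2 stands second highest of the three numbers. Its nearest neighbour is compound 3: a 2.7-fold lower number from compound 2 to compound 3 (0.43 log units; beyond the scatter), a modest step that lies beyond the scatter. For the measured compounds named here, compound 1 sits furthest away, at a higher number than compound 2, but the two differ in more than one place, so no single-point step links them.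

The next compound is compound 4 `COc1ccc(-c2nc3cc(F)ccc3s2)cc1O`. Against compound 2 the change is hydroxy in place of methyl on an aromatic carbon. Going by the values given here, the one measured step from compound 2, to compound 3, exchanges methyl for iodo at the same carbon; it says nothing about a hydroxy group, and no other pair carries a hydroxy. Among the compounds with values here, there is therefore no measured step that bears directly on this change. The expectation for this assay is a step from compound 2 to compound 4 that stays within the scatter or is at most modest, with the direction left open.

The estimate for compound 4 is 20000 nM, range 7000 nM to 60000 nM, which corresponds to an expected step of a 1.1-fold higher number from compound 2 to compound 4 (0.03 log units; within the scatter).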

Compound 4, concentration for 50% growth inhibition: 18400 nM
The estimate for compound 4 lay 1.1-fold (0.04 log units) above the measured number, within the range that was stated.
By their numbers in this assay, from the lowest: compound 3; then compounds 4 and 2 (each within the scatter of the next); then compound 1.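

In this assay the aromatic carbon ortho to a methoxy group now carries three groups on the same core, and hydroxy in place of methyl gives a 1.0-fold lower number from compound 2 to compound 4 (0.00 log units; within the scatter), so the hydrogen-bond donor and acceptor that enter with the hydroxy leave no readable mark on the number. Iodo now stands apart from both smaller groups: hydroxy in place of iodo gives a 2.7-fold higher number from compound 3 to compound 4 (0.43 log units; beyond the scatter), matching in size the earlier methyl-to-iodo step, a 2.7-fold lower number from compound 2 to compound 3 (0.43 log units; beyond the scatter), so among these three groups only iodo separates from the others at this carbon. Nothing available explains why methyl and hydroxy fall together or why iodo falls apart.

Going by these compounds, whether an amine, a carboxylic acid, a chloro group or a longer chain at this carbon would stay with methyl and hydroxy or move toward iodo remains open, and three groups are too few to set a trend for this position. Compound 1 differs from the fluoro compounds in more than one place, so what the fluoro group itself contributes in this assay cannot be read from the compounds at hand.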